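This account rests on a few compounds, and the source may have more. Where it says the series, first, only, none or still open, it means among the compounds named here.

Measured so far:
compound 1 `COC(=O)C1=C(C)NC(=O)NC1c1ccc(OC)cc1`: 59200 nM
compound 2 `COC(=O)C1=C(C)NC(=O)NC1c1ccc(O)cc1`: 17200 nM

Going by the values given here, in an assay for inhibition of beta-glucuronidase (Bos taurus), read by spectrophotometry, with a stated time of 30 min (a lower number here means a stronger inhibitor, a higher number a weaker inhibitor), compound 2 gives 17200 nM, the lower of the two numbers recorded; its only neighbour is compound 1, which in this assay gives 59200 nM. Among the compounds with values here, the single measured step, a 3.4-fold lower number from compound 1 to compound 2 (0.54 log units; beyond the scatter), is the change of hydrogen in place of methyl on an oxygen on an aromatic ring, and it is the sole movement recorded for the shared core so far.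

Compound 3 `COC(=O)C1=C(C)NC(=O)NC1c1ccc(O)c(Cl)c1` differs from compound 2 by chloro in place of hydrogen on an aromatic carbon, ortho to a hydroxy group and meta to a large group. Within the data shown here, no measured step bears on this change; the step from compound 1 to compound 2 concerns the oxygen substituent, not the ring carbons, so nothing measured tells how this assay answers a chloro entering the ring. The expectation rests only on compound 2 and on the absence of any contrary step: a small movement, not certainly beyond the scatter, is expected as a 1.7-fold lower number from compound 2 to compound 3 (0.24 log units; within the scatter). Compound 3 is therefore estimated at 10000 nM in this assay, with a range from 3500 nM to 35000 nM.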

Compound 3, half-maximal inhibitory concentration: 27200 nM
The estimate for compound 3 lay 2.7-fold (0.43 log units) below the measured number; low and high end bracket the measured number.
By their numbers in this assay, from the lowest: compounds 2 and 3 (each within the scatter of the next); then compound 1.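

In this assay the chloro on an aromatic carbon, ortho to a hydroxy group and meta to a large group, gives a 1.6-fold higher number from compound 2 to compound 3 (0.20 log units; within the scatter) and so leaves the number within the scatter of that of compound 2. Going by these compounds alone, this is the first measured change on a ring carbon of the series: the earlier step concerned only the group on the oxygen and lay beyond the scatter, whereas this one shows that a chloro at this position produces no movement that can be told apart from repeated measurement. No supporting data are available to explain this result.

From the compounds shown here alone, whether a fluoro, a bromo, a methyl or a methoxy on the same carbon would move the number beyond the scatter remains open, as does the answer of this assay to a chloro on any other ring carbon. Also open, going by these compounds, are whether the chloro would give the same small step with the methoxy of compound 1 in place of the hydroxy, and how the series would respond if a carboxylic acid or an amide replaced the ester on the shared core.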